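This account rests on a few compounds, and the source may have more. Where it says the series, first, only, none or still open, it means among the compounds named here.

In a functional assay on MCF7 cells (Homo sapiens) for antiproliferative activity, read by CellTiter-Glo, with a stated time of 5 days (a lower number here means a stronger inhibitor, a higher number a weaker inhibitor), compound 1 `CC/C(=C(/c1ccc(/C=C/C(=O)O)cc1)c1ccc2[nH]ncc2c1)c1ccccc1` reads 7.2 nM and compound 2 `CC/C(=C(/c1ccc(/C=C/C(=O)O)cc1)c1ccc(-c2cscn2)cc1)c1ccccc1` reads 120 nM. Compound 2 therefore holds the higher of the two numbers, and the gap to compound 1 lies beyond the scatter. Compound 3 `CC/C(=C(/c1ccc(/C=C/C(=O)O)cc1)c1ccc(N2CCCCC2)cc1)c1ccccc1` has not yet been measured. It differs from compound 2 by piperidin-1-yl in place of 1,3-thiazol-4-yl on an aromatic carbon, with piperidin-1-yl in place of 1,3-thiazol-4-yl on an aromatic carbon, para to a large group. Within the data shown here, no measured pair isolates a change at this place, so the expectation rests on compound 2 at 120 nM and remains loose. In this assay, no step beyond the scatter is expected, though a slightly higher number seems more likely than a lower one. The expected change is a 1.3-fold higher number from compound 2 to compound 3 (0.12 log units; within the scatter). The estimated value for compound 3 is 160 nM, with an expected range of 50 nM to 500 nM.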

Compound 3, half-maximal inhibitory concentration: 450 nM
Compound 3: the middle estimate sits 2.8-fold (0.45 log units) below what was measured, within the range that was stated.
By their numbers in this assay, from the lowest: compound 1; then compound 2; then compound 3.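

Among these compounds, exchanging 1,3-thiazol-4-yl for piperidin-1-yl on an aromatic carbon para to a large group gives a 3.8-fold higher number from compound 2 to compound 3 (0.57 log units; beyond the scatter) in this assay as the first readable step at this place, so the ring carried here matters to the read-out. The exchange changes ring size, aromatic character and hetero atom count together, and this single step cannot separate them. No measurement at hand explains the step, and the data give no cause for it.

On these data alone, whether morpholin-4-yl, dimethylamino or a plain phenyl ring at this place would read nearer compound 2 or compound 3 stays open. Also open, as far as these compounds go, is whether the step would hold if a primary amide replaced the carboxylic acid of the shared core.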